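Shortening the acid chain of compound 2

The source may hold more compounds than are shown below. What is called first, only, known or untested is meant among the compounds shown, and "the series" means these compounds.

In a functional assay on MDA-MB-435S cells (Homo sapiens) for cytotoxicity, read by MTT assay (on this read-out higher numbers stand for weaker inhibition and lower numbers for stronger inhibition), compound 1 `CCOC(=O)C(C)Oc1c(-c2ccc(OC)cc2)oc2c(CC=C(C)C)c(O)cc(O)c2c1=O` gives 4100 nM, compound 2 `COc1ccc(-c2oc3c(CC=C(C)C)c(OC/C=C/C(=O)O)cc(O)c3c(=O)c2O)cc1` gives 11300 nM and compound 3 `COc1ccc(-c2oc3c(CC=C(C)C)c(OC/C=C/C(=O)O)cc(O)c3c(=O)c2OC/C=C/C(=O)O)cc1` gives 57500 nM. Compound 2 thus stands second highest of the three, beyond the scatter from both neighbours. Compound 4 `COc1ccc(-c2oc3c(CC=C(C)C)c(OCC(=O)O)cc(O)c3c(=O)c2O)cc1` differs from it at one place: carboxy in place of 2-carboxyethenyl on a saturated chain carbon bound to an oxygen on an aromatic ring. Going by the values given here, the one measured step involving this chain is a 5.1-fold higher number from compound 2 to compound 3 (0.71 log units; beyond the scatter), which adds a second copy and does not shorten it, so it bears only loosely. Among the compounds with values here, no measured step tests shortening. The estimated step is a 1.2-fold higher number from compound 2 to compound 4 (0.06 log units; within the scatter), and none beyond the scatter is expected. For compound 4 the estimated value is 13000 nM, with an expected range from 5500 nM to 31000 nM.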

Compound 4, half-maximal inhibitory concentration: 13500 nM
Compound 4: the middle estimate sits 1.0-fold (0.02 log units) below what was measured; the measured number falls inside the stated range.
By their numbers in this assay, from the lowest: compound 1; then compounds 2 and 4 (each within the scatter of the next); then compound 3.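

In this assay, the step to the shorter chain reads a 1.2-fold higher number from compound 2 to compound 4 (0.08 log units; within the scatter), so on a saturated chain carbon bound to an oxygen on an aromatic ring, carboxy and 2-carboxyethenyl cannot be told apart. Going by these compounds alone, until now, the only measured change involving this chain was the addition of a second copy at another oxygen, a 5.1-fold higher number from compound 2 to compound 3 (0.71 log units; beyond the scatter), which said nothing about chain length at this place. Nothing measured on hand offers an explanation for the match between these two chains.

On these data alone, what an amine or an amide in place of the acid end would give remains open. So does the outcome of a longer saturated chain at this oxygen.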